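Series notes: one double bond in the chain of compound 2

The source may hold more compounds than are shown below. What is called first, only, known or untested is meant among the compounds shown, and "the series" means these compounds.

The shared core appears here in three forms. Compound 1 `CC/C=C\C/C=C\C/C=C\CCCCCCCc1cc(=O)c2c(O)cc(OCOC)cc2o1` carries an unsaturated chain, and in a functional assay on MCF7 cells (Homo sapiens) for antiproliferative activity, read by MTT assay (a higher number here means a weaker inhibitor, a lower number a stronger inhibitor), compound 1 gives 17500 nM. Compound 3 `CCCCCCCCCCCCCCCc1cc(=O)c2c(O)c(C)c(O)c(C)c2o1` carries a saturated chain; in this assay compound 3 gives > 67200 nM, which is a limit of the assay and not a number. Compound 2 `CCCCCCCCCCCCCCCC1(O)CC(=O)c2c(O)cc(OCOC)cc2O1` carries a saturated chain on a saturated ring carbon. In this assay compound 2 gives > 67200 nM, again a limit of the assay and not a number. Compound 2 therefore stands at the limit of > 67200 nM in this assay, at which 2 of the 3 values shown sit.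

Compound 4 `CCCC/C=C\CCCCCCCCCC1(O)CC(=O)c2c(O)cc(OCOC)cc2O1` differs from compound 2 in one place: hex-1-en-1-yl in place of hexyl on a saturated chain carbon, nine bonds along the chain from a saturated ring carbon. Within the data shown here, no step between measured compounds of this kind is available. Since compound 2 sits at a limit, no change beyond the scatter is expected, and a further limit is the more likely outcome. The step from compound 2 to compound 4 is expected to read an at least 1.1-fold lower number from compound 2 to compound 4 (0.04 log units; that floor lies within the scatter). For compound 4 the estimate in this assay is 60000 nM, expected to fall between 20000 nM and 150000 nM.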

Compound 4, half-maximal inhibitory concentration: 43200 nM
Beside the measured number, compound 4's estimate is 1.4-fold (0.14 log units) above it; measured number inside the range.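

In this assay, hex-1-en-1-yl in place of hexyl on a saturated chain carbon, nine bonds along the chain from a saturated ring carbon, gives an at least 1.5-fold lower number from compound 2 to compound 4 (0.19 log units; that floor lies within the scatter). Compound 4 is the first compound shown with a saturated ring carbon to read as a number and not as a limit, so a chain with one double bond at this place can give a measurable value in this form of the core. The step can be stated only as a floor because compound 2 sits at a limit: the limit of > 67200 nM in this assay, at which 2 of the 4 values shown sit.

The compounds shown leave open whether the reading depends on where the double bond stands, as with oct-3-en-1-yl in place of octyl. Also open, as far as these compounds go, is how a longer chain or a carboxylic acid in place of hex-1-en-1-yl would read.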